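Trimming the Side Group: Ethyl in Place of Phenyl

The source may hold more compounds than are shown below. What is called first, only, known or untested is meant among the compounds shown, and "the series" means these compounds.

Compound 2 `Cc1nc(N)sc1CCCN/C(N)=N/C(=O)NC(c1ccccc1)c1ccccc1` gives 39.8 nM in a functional assay on Right cardiac atrium for agonist activity at histamine H2 receptor (Cavia porcellus), with a stated time of 30 min, in the presence of a further agent that is not named here; a lower number here means that less compound is needed, a higher number that more compound is needed for the effect. Its only neighbour, compound 1 `Cc1nc(N)sc1CCCN/C(N)=N/C(=O)NC(c1ccccc1)C(C)C`, gives 34.7 nM in this assay, and the step of a 1.1-fold higher number from compound 1 to compound 2 (0.06 log units; within the scatter) lies within the scatter, so compound 2 stands together with compound 1 on the numbers shown. Compound 3 `CCC(NC(=O)/N=C(\N)NCCCc1sc(N)nc1C)c1ccccc1` differs from compound 2 by ethyl in place of phenyl on a saturated chain carbon bound to an amide-type nitrogen and an aromatic carbon. Within the data shown here, only that one earlier step bears on this change, and it was flat, so no step beyond the scatter is expected from compound 2 to compound 3 in this assay. Compound 3 is therefore expected to give 45 nM, between 20 nM and 100 nM, a step of a 1.1-fold higher number from compound 2 to compound 3 (0.05 log units; within the scatter).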

Compound 3, half-maximal effective concentration: 10.7 nM
For compound 3 the middle estimate is 4.2-fold (0.62 log units) above the measured one; the measured number lies below the stated range.
By their numbers in this assay, from the lowest: compound 3; then compounds 1 and 2 (each within the scatter of the next).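

The flat step between isopropyl and phenyl hid a real sensitivity at this position: in this assay, ethyl gives a 3.7-fold lower number from compound 2 to compound 3 (0.57 log units; beyond the scatter) and, against isopropyl, a 3.2-fold lower number from compound 1 to compound 3 (0.51 log units; beyond the scatter). So this place does respond to the side group, and of the three groups shown, ethyl needs the least compound for the effect. Nothing shown explains this shift. On these data alone, whether methyl or a longer chain such as propyl would lower the number further remains open. So does whether a group carrying an amine or a hydroxyl would be tolerated here.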